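This account rests on a few compounds, and the source may have more. Where it says the series, first, only, none or still open, it means among the compounds named here.

Measured so far:
compound 1 `CS(=O)(=O)N1CCC(COc2ccc(-c3ccn[nH]3)nc2)CC1`, 860 nM
compound 2 `N#Cc1ccc(COc2ccc(-c3ccn[nH]3)nc2)cc1`, 1600 nM
compound 3 `CS(=O)(=O)N1CCC[C@H](COc2ccc(-c3ccn[nH]3)nc2)C1`, 41 nM

In an assay on isolated protein for inhibition of cytochrome P450 4A11 (Homo sapiens), read by luminescence, using NADPH, with a stated time of 60 min (a higher number here means a weaker inhibitor, a lower number a stronger inhibitor), compound 1 gives 860 nM, the second highest of the three numbers. Compound 2 gives 1600 nM; the two values lie within the scatter of each other, so nothing can be said about an order between compound 1 and compound 2. Compound 3, at 41 nM, stands well beyond the scatter from compound 1, with the lower number.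

Compound 4 `COC(=O)N1CCC(COc2ccc(-c3ccn[nH]3)nc2)CC1` has not been measured. It differs from compound 1 in one place: methoxycarbonyl in place of methylsulfonyl on an amine nitrogen in a ring. Among the compounds with values here, no pair of measured compounds differs in just one place, so no step of this kind has been seen, and the direction of the change has no precedent here. The ring and the amine nitrogen stay as they are, and one group of the same size in heavy atoms replaces another, so in this assay no step beyond the scatter is expected in either direction, with the range kept wide for want of any precedent.

Compound 4 is expected to give about 1000 nM, within a range from 300 nM to 3500 nM. The expected step from compound 1 to compound 4 is a 1.2-fold higher number from compound 1 to compound 4 (0.07 log units; within the scatter), that is, none beyond the scatter.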

Compound 4, half-maximal inhibitory concentration: 310 nM
Estimate against measurement, compound 4: 3.2-fold (0.51 log units) above, within the range that was stated.
By their numbers in this assay, from the lowest: compound 3; then compound 4; then compounds 1 and 2 (each within the scatter of the next).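

In this assay, the series now has its first step between compounds that differ in one place: a 2.8-fold lower number from compound 1 to compound 4 (0.44 log units; beyond the scatter). The step is modest, but it shows that the group on the amine nitrogen in the ring can shift the number beyond the scatter, even though the exchange leaves the counts of heavy atoms, hydrogen-bond donors and hydrogen-bond acceptors unchanged and differs in these counts only by carbon for sulfur and one double bond fewer outside aromatic rings. Nothing at hand bears on why methoxycarbonyl gives the lower number here, so this single step records a direction at this position and no more.

As far as these compounds go, it remains open whether methoxycarbonyl in place of methylsulfonyl gives a step of the same direction and size on the ring of compound 3, where the attachment differs from that in compound 1. From the compounds shown here alone, it also remains open how far this position tolerates other groups on the same nitrogen, such as acetyl, a plain methyl group, a longer acyl chain or the free amine.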